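The compounds below may be only part of what the source reports. "The series", "measured", "known", "first", "only" and "open" are said of these compounds alone.

Compound 1 `Cc1cc(C)c(-c2nc(CN3CCC(C(=O)NCCCN4C[C@H](C)C[C@H](C)C4)CC3)c(C)o2)c(C)c1`: "not determined" (no result reported)
Compound 2 `Cc1oc(-c2c(Br)cccc2Br)nc1CN1CCC(C(=O)NCCCN2C[C@H](C)C[C@H](C)C2)CC1`: < 1 10^-6 cm/s
Compound 3 `COc1cccc(F)c1-c1nc(CN2CCC(C(=O)NCCCN3C[C@H](C)C[C@H](C)C3)CC2)c(C)o1`: "not determined" (no result reported)

In a physicochemical assay for permeability, using PAMPA (on this read-out higher numbers stand for higher permeability and lower numbers for lower permeability), compound 3 stands without a number, since its entry reads "not determined" (no result reported). The entry for compound 1 is the same, "not determined" (no result reported). Compound 2 gives < 1 10^-6 cm/s, which is a limit of the assay and not a number.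

The next structure is compound 4 `Cc1cc(C)cc(-c2nc(CN3CCC(C(=O)NCCCN4C[C@H](C)C[C@H](C)C4)CC3)c(C)o2)c1`. The change, (3,5-dimethylphenyl in place of 2-fluoro-6-methoxyphenyl on an aromatic carbon), puts 3,5-dimethylphenyl in place of 2-fluoro-6-methoxyphenyl on an aromatic carbon. The rest of the molecule stays the same.

With no number for compound 3, there is no starting value from which to measure a step. Even so, no step beyond the usual scatter is expected in this assay, and no direction can be favoured. The closest guide is compound 2, whose result is the limit < 1 10^-6 cm/s. A reading close to that limit therefore seems likely, and the assay may again report only a limit.

The expected value for compound 4 is 0.7 10^-6 cm/s, with an estimated range of 0.2 10^-6 cm/s to 3 10^-6 cm/s.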

Compound 4, apparent permeability: 864 10^-6 cm/s
For compound 4 the middle estimate is 1200-fold (3.09 log units) below the measured one; measured number above the stated range.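

For the compounds shown here, compound 4 gives the first true number in this set, which shows for the first time that the group on this aromatic carbon can matter in this assay. Compound 2 gives < 1 10^-6 cm/s, which is a limit of the assay and not a number. With the rest of the molecule unchanged, 3,5-dimethylphenyl in place of 2,6-dibromophenyl gives an at least 860-fold higher number from compound 2 to compound 4 (2.93 log units; beyond the scatter), while the change from compound 3 cannot be read, since compound 3 has no number.

The compounds shown leave open whether this step follows from methyl replacing bromine or from where these groups sit on the phenyl ring, since both differ together here. A 3,5-dibromophenyl group or a plain phenyl ring on this carbon would help separate the two.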